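This account rests on a few compounds, and the source may have more. Where it says the series, first, only, none or still open, it means among the compounds named here.

Compound 1 `CNC(=O)c1cc(C(=O)NC2CC2)cn([C@H](C)c2ccccc2)c1=O` gives in a physicochemical assay for solubility (on this read-out higher numbers stand for higher solubility and lower numbers for lower solubility), the value >= 168 ug/mL, which is a limit of the assay and not a number.
Compound 2 `CNC(=O)c1cc(C(=O)NC2CC2)cn(Cc2cccc3[nH]ccc23)c1=O` gives in this assay the value 78 ug/mL.
Compound 3 `CNC(=O)c1cc(C(=O)NC2CCC2)cn(Cc2cccc(NC)c2)c1=O` gives in this assay the value >= 155 ug/mL, again a limit of the assay rather than a number.

Among these three, compound 2 is the only one with a plain number in this assay; the other two sit at limits, as the limit of >= 155 ug/mL in this assay, at which 1 of the 3 values shown sits, and the limit of >= 168 ug/mL in this assay, at which 1 of the 3 values shown sits, show. Compound 4 `CNC(=O)c1cc(C(=O)NC2CC2)cn(Cc2ccc3nc[nH]c3c2)c1=O` has not yet been measured. It differs from compound 2 in one place: 1H-benzimidazol-6-yl in place of 1H-indol-4-yl on a saturated chain carbon bound to an aromatic nitrogen. Among the measured compounds shown here, no measured step between two compounds is available to set the scale of this change. The step from compound 2 to compound 4 in this assay is expected to be a 1.4-fold higher number from compound 2 to compound 4 (0.15 log units; within the scatter), a modest rise that may not exceed the usual scatter. Compound 4 is therefore estimated at 110 ug/mL, with a range from 50 ug/mL to 240 ug/mL.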

Compound 4, solubility: >= 163 ug/mL
Compound 4 was reported as a limit (the forecaster's own chance of this, stated with the estimate: 20%); middle value at least 1.4-fold (0.17 log units) away from the limit.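

Among the compounds shown here, the change of 1H-indol-4-yl to 1H-benzimidazol-6-yl on a saturated chain carbon bound to an aromatic nitrogen gives the first readable step at this position in this assay: an at least 2.0-fold higher number from compound 2 to compound 4 (0.32 log units; beyond the scatter). The earlier compounds shown here offered no such comparison, and this one shows that the group at this place can move the read-out beyond the scatter. Compound 4 is reported as a limit of the assay and not as a number, so the full size of the step stays unknown: the limit of >= 163 ug/mL in this assay, at which 1 of the 4 values shown sits.

The compounds shown do not separate the added ring nitrogen from the changed point of attachment, which 1H-benzimidazol-4-yl could do. They also leave open how a carboxylic acid or an amine at this place would compare.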